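Thiazolyloxy in Place of Pyridinyl on a Shared Core

This account rests on a few compounds, and the source may have more. Where it says the series, first, only, none or still open, it means among the compounds named here.

Compound 1 `O=C1C(=O)N(Cc2ccc(-c3cccnc3)cc2)c2ccc(OC(F)(F)F)cc21` gives 51% in a functional assay on CHO cells for positive allosteric modulation of muscarinic acetylcholine receptor M5 (Homo sapiens), read by FLIPR and calcium flux, with a stated time of 1 h (a lower number here means a smaller maximal response, a higher number a larger maximal response), the second highest of the three numbers shown. Compound 3 `O=C1C(=O)N(Cc2ccc(-c3ccncc3)nc2)c2ccc(OC(F)(F)F)cc21` sits nearest, with 50%, within the scatter; compound 2 `O=C1C(=O)N(Cc2ccc(-c3ccccc3)nc2)c2ccc(OC(F)(F)F)cc21` stands furthest, with 76%, beyond it. Among the compounds with values here, the single measured step, a number 26 percentage points lower from compound 2 to compound 3 (beyond the scatter), swaps one aromatic group for another at the far end of the molecule. Compound 4 `O=C1C(=O)N(Cc2ccc(Oc3nccs3)cc2)c2ccc(OC(F)(F)F)cc21` differs from compound 1 by (1,3-thiazol-2-yl)oxy in place of pyridin-3-yl on an aromatic carbon. Within the data shown here, no measured step covers an exchange of this kind, and the only related swap lowered the response modestly, so for compound 4 a small step in this assay, direction uncertain, is expected: a number 4 percentage points higher from compound 1 to compound 4 (within the scatter). The estimate for compound 4 is 55%, within 35% to 75%.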

Compound 4, largest response reached (Emax), in percent of the reference or control that the assay uses: 58%
Estimate against measurement, compound 4: 3 percentage points below; measured number inside the range.
By their numbers in this assay, from the lowest: compounds 3, 1 and 4 (each within the scatter of the next); then compound 2.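

In this assay, placing (1,3-thiazol-2-yl)oxy in place of pyridin-3-yl, para to a large group, gives a number 7 percentage points higher from compound 1 to compound 4 (within the scatter). This position therefore accepts a five-membered aromatic ring attached through oxygen as well as a directly attached six-membered one, with no change that can be told from the scatter, whereas the step of a number 26 percentage points lower from compound 2 to compound 3 (beyond the scatter) was beyond it. Nothing shown accounts for this result. On these data alone, it remains open how a phenoxy group, which would keep the oxygen but carry a six-membered ring, or a morpholine would fare at this position.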